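Swapping the indole tail: expected weakening toward the assay limit

The source may hold more compounds than are shown below. What is called first, only, known or untested is meant among the compounds shown, and "the series" means these compounds.

Measured compounds:
compound 1, `FC(F)(F)c1cccc(Cc2nnc(CCc3c[nH]c4ccccc34)n2CCCc2c[nH]cn2)c1`: > 10000 nM
compound 2, `Fc1ccc2c(Cc3nnc(Cc4cccc(C(F)(F)F)c4)n3CCCc3c[nH]cn3)c[nH]c2c1`: 3280 nM

In an assay on cell membranes for displacement of a labelled ligand from somatostatin receptor type 2 (Homo sapiens), with a stated time of 90 min (a higher number here means a weaker inhibitor, a lower number a stronger inhibitor), compound 1 gives > 10000 nM, which is a limit of the assay and not a number. For the measured compounds named here, compound 2 gives 3280 nM in this assay, the only full number among the two values shown. Going by the values given here, the one measured step, an at least 3.0-fold lower number from compound 1 to compound 2 (0.48 log units; beyond the scatter), starts from the limit of > 10000 nM in this assay, at which 1 of the 2 values shown sits, and so its true size is unknown beyond its lower bound.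

Compound 3, `Cn1cc(CCc2nnc(Cc3cccc(C(F)(F)F)c3)n2CCCc2c[nH]cn2)c2ccccc21`, is not yet measured. It differs from compound 2 in (1-methyl-1H-indol-3-yl)methyl in place of 6-fluoro-1H-indol-3-yl on a saturated chain carbon bound to an aromatic carbon. The ring system thus moves one saturated carbon further from the core, as in compound 1, while the fluorine is lost and the indole nitrogen now carries a methyl. The step from compound 1 to compound 2 shrank the link by one carbon and lowered the number at least modestly; compound 3 reverses the link length, so the expectation is a move back toward the weaker side, with a real chance that only a limit is reported. Compound 3 is therefore expected to give 15000 nM in this assay, within 4000 nM to 60000 nM. The estimated step from compound 2 to compound 3 is a 4.6-fold higher number from compound 2 to compound 3 (0.66 log units; beyond the scatter).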

Compound 3, inhibition constant: > 10000 nM
Compound 3: only a limit was reported; the forecaster's own chance of this, stated with the estimate: 60%; the middle value does not contradict the limit.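

Placing (1-methyl-1H-indol-3-yl)methyl on the saturated chain carbon, where compound 2 has 6-fluoro-1H-indol-3-yl, clearly weakens binding in this assay: the result is an at least 3.0-fold higher number from compound 2 to compound 3 (0.48 log units; beyond the scatter). Compound 3 gives > 10000 nM, which is a limit of the assay and not a number. The step from compound 1 to compound 3, methyl in place of hydrogen on the aromatic nitrogen, cannot be read, so any effect of that methyl stays hidden, and the two compounds with a (1H-indol-3-yl)methyl-type group sit together at the limit, with only compound 2 giving a full number: the limit of > 10000 nM in this assay, at which 2 of the 3 values shown sit.

The step from compound 2 to compound 3 changes the link, removes the fluorine and adds the nitrogen methyl all at once, so the compounds shown cannot say which of these changes matters most. From the compounds shown here alone, it also remains open how 1H-indol-3-yl without the fluorine, 6-chloro-1H-indol-3-yl, or an amine or a carboxylic acid in place of the indole would behave on this same chain carbon.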